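This account rests on a few compounds, and the source may have more. Where it says the series, first, only, none or still open, it means among the compounds named here.

In a functional assay (aorta) for inhibition, with Rattus norvegicus as the target (on this read-out lower numbers stand for stronger inhibition and higher numbers for weaker inhibition), compound 2 `CC(C)/N=C(\NC#N)Nc1ccc(C#N)cc1` gives 19000 nM. That value lies within the scatter of compound 3 `CCC(C)(C)/N=C(\NC#N)Nc1cccc(S(=O)(=O)N2CCCCC2)c1` at 12800 nM, whereas compound 1 `CC(/N=C(\NC#N)Nc1ccccc1)C(C)(C)C` shows clearly stronger inhibition at 980 nM. Compound 4 `CCC(C)(C)/N=C(\NC#N)Nc1ccc(C#N)cc1` is compound 2 with a single change: ethyl in place of hydrogen on a saturated chain carbon bound to a double-bonded nitrogen and two saturated chain carbons, which turns isopropyl into 1,1-dimethylpropyl. Within the data shown here, no measured pair isolates this change, so any forecast is loose. Compound 1, at 980 nM, has a chain larger than isopropyl but also differs from compound 2 elsewhere. Compound 3 goes against a simple trend, since it carries 1,1-dimethylpropyl yet sits level with compound 2. A moderate gain in inhibition is therefore expected, an estimated 6.3-fold lower number from compound 2 to compound 4 (0.80 log units; beyond the scatter). Compound 4 is expected at 3000 nM, with an estimated range of 600 nM to 12000 nM.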

Compound 4, half-maximal inhibitory concentration: 130 nM
Beside the measured number, compound 4's estimate is 23-fold (1.36 log units) above it, outside the stated range (below it).
By their numbers in this assay, from the lowest: compound 4; then compound 1; then compounds 3 and 2 (each within the scatter of the next).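

In this assay the swap of isopropyl for 1,1-dimethylpropyl gives a 150-fold lower number from compound 2 to compound 4 (2.16 log units; beyond the scatter) with nothing else in the molecule changed. Among these compounds, this pair is the first to isolate the position, and it shows that the added ethyl on that saturated chain carbon is enough by itself for a large gain in inhibition. Nothing shown here explains the size of this step. From the compounds shown here alone, whether a longer chain such as 1,1-dimethylbutyl would gain further at this carbon stays open, as does the effect of an amine on that chain.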